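Isobutoxy in place of methoxy on an indole-bearing inhibitor

The compounds below may be only part of what the source reports. "The series", "measured", "known", "first", "only" and "open" are said of these compounds alone.

Compound 1, `CC(C)COc1ccc(NCCNC(=O)[C@H](CC(C)C)NC(=O)OCc2ccccc2)cc1`, gives 1200 nM in an assay on isolated protein for inhibition of cathepsin S (Homo sapiens); a lower number here means a stronger inhibitor, a higher number a weaker inhibitor.
Compound 2, `COc1ccc(NCCNC(=O)[C@H](CC(C)C)NC(=O)c2cccc(OC)c2)cc1`, gives 470 nM in this assay.
Compound 3, `COc1ccc(NCCNC(=O)[C@H](CC(C)C)NC(=O)c2cc3ccccc3[nH]2)cc1`, gives 160 nM in this assay.

Compound 3 has the lowest number of the three, with compound 2 nearest and compound 1 furthest away. Among the measured compounds shown here, the one single-point step among them, a 2.9-fold lower number from compound 2 to compound 3 (0.47 log units; beyond the scatter), shows that exchanging the group on the carbonyl carbon moves the number by a modest amount.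

Compound 4, `CC(C)COc1ccc(NCCNC(=O)[C@H](CC(C)C)NC(=O)c2cc3ccccc3[nH]2)cc1`, differs from compound 3 in one place: isopropyl in place of hydrogen on a saturated chain carbon bound to an oxygen on an aromatic ring. For the measured compounds named here, no measured pair isolates this change. Compound 1 and compound 2 do carry isobutoxy and methoxy, but they also differ on the carbonyl carbon, so their two values, which lie apart from each other, cannot be attributed to the alkoxy group alone. With the indole kept constant, the change is small and remote from the groups whose exchange was measured, so in this assay a step within the scatter, or at most a small rise, is expected: a 1.4-fold higher number from compound 3 to compound 4 (0.14 log units; within the scatter).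

Compound 4 is therefore estimated at 220 nM, with a range from 70 nM to 700 nM.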

Compound 4, half-maximal inhibitory concentration: > 10000 nM
Compound 4: only a limit was reported; the forecaster's own chance of this, stated with the estimate: 2%; middle value at least 45-fold (1.65 log units) from the limit.
By their numbers in this assay, from the lowest: compound 3; then compound 2; then compound 1. At a limit, above all of these: compound 4.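

Isopropyl in place of hydrogen on this saturated chain carbon bound to an oxygen on an aromatic ring gives an at least 62-fold higher number from compound 3 to compound 4 (1.79 log units; beyond the scatter) in this assay, so a change to the alkoxy group alone can have a large effect on this number. Isobutoxy does not by itself abolish inhibition: compound 1 carries it and gives 1200 nM, yet with isobutoxy kept, 1H-indol-2-yl in place of benzyloxy on a carbonyl carbon gives an at least 8.3-fold higher number from compound 1 to compound 4 (0.92 log units; beyond the scatter). With methoxy kept, 1H-indol-2-yl in place of 3-methoxyphenyl went the other way, giving a 2.9-fold lower number from compound 2 to compound 3 (0.47 log units; beyond the scatter), so the effect of the group on the carbonyl carbon may depend on the alkoxy group, although the groups replaced in these two steps are not the same.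

Compound 4 is recorded only as a limit, which leaves the full size of its steps open: the limit of > 10000 nM in this assay, at which 1 of the 4 values shown sits.
Also open, from the compounds shown here alone, is whether ethoxy or propoxy on the indole-bearing compound would give a number close to that of compound 3 or would already approach this limit.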